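A few compounds are considered here, and "the series" means these few. Any claim that something is new, unique, unknown or untested is made for them only; others in the source may bear on it.

Compound 1 `O=C(O)C1(CCCc2ccc(Cl)cc2)CO1`: 180 umol/kg
Compound 2 `O=C(O)C1(CCCCCc2ccc(Cl)cc2)CO1`: 30 umol/kg
Compound 3 `CCOC(=O)C1(CCCCCCCc2ccc(Cl)cc2)CO1`: 270 umol/kg

All three numbers come from a functional assay on the whole organism (blood) with Rattus norvegicus as the target; on this read-out higher numbers stand for an effect only at larger amounts of compound and lower numbers for an effect already at smaller amounts. Compound 1 stands second highest of the three; its nearest neighbour is compound 3, within the scatter, and its furthest is compound 2, beyond the scatter. Compound 4 `CCOC(=O)C1(CCCc2ccc(Cl)cc2)CO1` is not yet measured. It differs from compound 1 by ethyl in place of hydrogen on an oxygen next to a carbonyl group. Within the data shown here, no measured pair shows this change on its own; compound 3 carries the same ethoxycarbonyl but on a longer chain, so its number cannot be read as the effect of the ester alone. The step is expected to be small, in no fixed direction, and within the scatter. Compound 4 is estimated at 200 umol/kg in this assay, with a range from 70 umol/kg to 550 umol/kg. This estimate means an expected step of a 1.1-fold higher number from compound 1 to compound 4 (0.05 log units; within the scatter).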

Compound 4, dose for half-maximal effect: 200 umol/kg
The estimate for compound 4 equals the measured number at the digits printed, within the range that was stated.
By their numbers in this assay, from the lowest: compound 2; then compounds 1, 4 and 3 (each within the scatter of the next).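

In this assay, ethyl in place of hydrogen on an oxygen next to a carbonyl group can now be read on its own, as a 1.1-fold higher number from compound 1 to compound 4 (0.05 log units; within the scatter). At this chain length, the carboxy and ethoxycarbonyl forms therefore cannot be told apart on this read-out. Nothing available accounts for this result. Still open, going by these compounds, is whether the carboxy to ethoxycarbonyl change stays this small on the longer chains of compound 2 and compound 3. Also open, on these data alone, is how an amide or a benzyl ester would read at the same place.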